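Furan-2-yl in Place of Phenyl: What to Expect

The source may hold more compounds than are shown below. What is called first, only, known or untested is meant among the compounds shown, and "the series" means these compounds.

Measured compounds and their values:
Compound 1, `COc1ccc(C(c2ccccc2)c2nc(-c3ccc(Cl)cc3)c(CC(=O)O)s2)cc1`, gives 76 nM.
Compound 2, `O=C(O)Cc1sc(C(c2ccc(F)cc2)c2ccc(F)cc2)nc1-c1ccccc1`, gives 240 nM.
Compound 3, `COc1ccc(OC)c(-c2nc(C(c3ccccc3)c3ccccc3)sc2CC(=O)O)c1`, gives > 100000 nM, which is a limit of the assay rather than a number.

All three were tested in an in vitro functional assay on HEK285-7 cells for antagonist activity at prostaglandin D2 receptor 2 (Homo sapiens), read by BRET and beta-arrestin recruitment; a lower number here means a stronger inhibitor, a higher number a weaker inhibitor. Among the two values that are numbers, compound 2 has the higher one; its nearest neighbour is compound 1, whose number is lower by a step that lies beyond the usual scatter. The value of compound 3 sits at the limit of > 100000 nM in this assay, at which 1 of the 3 values shown sits, so it is a limit and not a number.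

Compound 4, `O=C(O)Cc1sc(C(c2ccc(F)cc2)c2ccc(F)cc2)nc1-c1ccco1`, has not yet been measured in this assay. It differs from compound 2 in one place: furan-2-yl in place of phenyl on an aromatic carbon. For the measured compounds named here, no measured pair shows exactly this change, so the expectation rests on compound 2 alone. The step from compound 2 to compound 4 is expected to be small, a 1.7-fold higher number from compound 2 to compound 4 (0.22 log units; within the scatter), toward a weaker inhibitor but not clearly beyond the scatter. Compound 4 is therefore estimated at 400 nM, within a range from 100 nM to 2000 nM.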

Compound 4, half-maximal inhibitory concentration: 140 nM
Compound 4: middle estimate off by 2.9-fold (0.46 log units), on the high side; the measured number falls inside the stated range.
By their numbers in this assay, from the lowest: compounds 1, 4 and 2 (each within the scatter of the next, the first and the last beyond it). At a limit, above all of these: compound 3.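

In this assay, replacing phenyl with furan-2-yl gives a 1.7-fold lower number from compound 2 to compound 4 (0.23 log units; within the scatter). For the compounds shown here, this is the first sign that the position next to the ring nitrogen can hold something other than a six-membered carbon ring: a five-membered aromatic ring with one oxygen and one hydrogen-bond acceptor gives a number that cannot be told apart from that of the phenyl compound. No measurement shown here accounts for this outcome.

A single pair leaves open whether the same swap would hold on a different core, such as that of compound 1, which carries a different group at this position and different groups on its other side. Also open, as far as these compounds go, is how this position would respond to a thiophen-2-yl ring, a pyridine ring, a saturated cyclohexyl ring or a small methyl group.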